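Thiourea to sulfonyl on the ring nitrogen of compound 2

The source may report more compounds than this note shows. Statements on the series, on what has been measured and on what is new or still open speak of the compounds shown alone.

Of the compounds shown here, three that share one core have been tested in an assay on cells for inhibition of Pendrin (Mus musculus), read by fluorescence, with a stated time of 10 min; on this read-out higher numbers stand for weaker inhibition and lower numbers for stronger inhibition. Compound 1 `Cn1nc(COc2cccc(F)c2)c2c1CCN(C(=O)Nc1ccc(Cl)cc1)C2` carries a urea on the ring nitrogen and gives 6600 nM. Compound 2 `Cn1nc(COc2cc(F)cc(F)c2)c2c1CCN(C(=S)Nc1ccc(Cl)cc1)C2` carries a thiourea instead, and in this assay compound 2 reaches only the limit > 10000 nM. Compound 3 `CN(C)c1ccc(NC(=S)N2CCc3c(c(COc4cc(F)cc(F)c4)nn3C)C2)cc1`, with dimethylamino in place of chloro on an aromatic carbon, likewise gives only the limit > 10000 nM. The step that the two limits leave unreadable from compound 2 to compound 3 therefore cannot be sized, because of the limit of > 10000 nM in this assay, at which 2 of the 3 values shown sit.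

Compound 4 `Cn1nc(COc2cc(F)cc(F)c2)c2c1CCN(S(=O)(=O)c1ccc(Cl)cc1)C2` differs from compound 2 by a group of 10 heavy atoms (6 carbon, 2 oxygen, 1 sulfur, 1 chlorine; one six-membered aromatic ring of carbon only) in place of a group of 10 heavy atoms (7 carbon, 1 nitrogen, 1 sulfur, 1 chlorine; one six-membered aromatic ring of carbon only), on an amine nitrogen in a ring. Among the compounds with values here, no measured step touches this exchange; the single step recorded stays unreadable, and compound 2 itself stands only as a limit. On the numbers shown, compound 4 is expected to remain weak, with an estimated 12000 nM and a likely range from 3000 nM to 50000 nM. The step that the limit leaves unreadable from compound 2 to compound 4 that this estimate implies is expected to be small or unreadable, since compound 2 offers only a limit as its starting point.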

Compound 4, half-maximal inhibitory concentration: > 10000 nM
Compound 4: no number, only a limit (the forecaster's own chance of this, stated with the estimate: 65%); the middle value lies beyond the limit too.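

In this assay compound 4 gives only a limit, > 10000 nM. No step from compound 2 to compound 4 can be read because compound 2 also stands only as a limit: the limit of > 10000 nM in this assay, at which 3 of the 4 values shown sit.

The compounds shown leave open how (4-chlorophenyl)sulfonyl on the amine nitrogen in a ring compares with the thiourea of compound 2.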